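Methyl in place of ring hydrogen on the carbamate series

A few compounds are considered here, and "the series" means these few. Any claim that something is new, unique, unknown or untested is made for them only; others in the source may bear on it.

Compound 1 `CCC(COc1ccccc1)OC(=O)NCc1ccccc1` is the parent of the series. In an assay for inhibition of zeta-carotene desaturase, chloroplastic/chromoplastic (Capsicum annuum), using a Dixon plot, with a stated time of 8 h (on this read-out higher numbers stand for weaker inhibition and lower numbers for stronger inhibition), compound 1 sits at the limit of the assay, giving > 100000 nM, which is a limit and not a number. Compound 2 `CCC(COc1cccc(C#N)c1)OC(=O)NCc1ccccc1` carries cyano in place of hydrogen on an aromatic carbon; in this assay compound 2 likewise reaches only the limit, > 100000 nM. Compound 3 `CCC(COc1cccc([N+](=O)[O-])c1)OC(=O)NCc1ccccc1` carries nitro in place of hydrogen on an aromatic carbon, and in this assay compound 3 also stops at the limit, > 100000 nM. The steps are therefore unreadable: a step that the two limits leave unreadable from compound 1 to compound 2, a step that the two limits leave unreadable from compound 1 to compound 3 and a step that the two limits leave unreadable from compound 2 to compound 3, because of the limit of > 100000 nM in this assay, at which 3 of the 3 values shown sit.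

Compound 4 `CCC(COc1cccc(C)c1)OC(=O)NCc1ccccc1` differs from compound 1 by methyl in place of hydrogen on an aromatic carbon. Within the data shown here, no measured step gives a readable size for a ring substitution, so no direction can be drawn from them. Given that compound 1 shows > 100000 nM, compound 4 is expected to show a step that the limit leaves unreadable from compound 1 to compound 4, that is, most likely another limit. The estimate for compound 4 in this assay is 150000 nM, with a range from 40000 nM to 1000000 nM.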

Compound 4, half-maximal inhibitory concentration: > 100000 nM
Compound 4 ended at the assay's limit; the forecaster's own chance of this, stated with the estimate: 85%; the middle value does not contradict the limit.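

No new step can be read between compound 4 and compound 1, compound 2 or compound 3 in this assay, because all four stop at one limit: the limit of > 100000 nM in this assay, at which 4 of the 4 values shown sit.

The compounds shown leave open whether any ring substituent on the shared core gives a readable value in this assay, and in which direction such a step would run.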